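Working notes: exchanging one fluorinated group in compound 1

The compounds below may be only part of what the source reports. "The series", "measured", "known", "first", "only" and "open" are said of these compounds alone.

In a functional assay on VCaP cells (Homo sapiens) for antiproliferative activity, read by propidium iodide staining, with a stated time of 96 h (on this read-out lower numbers stand for stronger inhibition and higher numbers for weaker inhibition), compound 1 (`CC(O)(COc1ccc(S(F)(F)(F)(F)F)cc1)C(=O)Nc1ccc(S(F)(F)(F)(F)F)cc1`) gives 9300 nM and compound 2 (`CC(O)(COc1ccc(OC(F)(F)F)cc1)C(=O)Nc1ccc(S(F)(F)(F)(F)F)cc1`) gives 12800 nM, a pair within the scatter of each other. Compound 3 (`CC(O)(COc1ccc(S(F)(F)(F)(F)F)cc1)C(=O)Nc1ccc(C(F)(F)F)cc1`) is still unmeasured and, relative to compound 1, carries a group of 4 heavy atoms (1 carbon, 3 fluorine; no ring) in place of a group of 6 heavy atoms (5 fluorine, 1 sulfur; no ring), on an aromatic carbon in its structure. Among the compounds with values here, the only measured step (a 1.4-fold higher number from compound 1 to compound 2 (0.14 log units; within the scatter)) lies within the scatter but changes a different aromatic carbon, so it bears only loosely on this exchange. On that thin basis, no shift beyond the scatter is expected in this assay for this change. The expected step (a 1.3-fold higher number from compound 1 to compound 3 (0.11 log units; within the scatter)) is therefore small. Compound 3 is estimated at 12000 nM (expected range 5000 nM to 28000 nM).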

Compound 3, half-maximal inhibitory concentration: 14700 nM
Compound 3: middle estimate off by 1.2-fold (0.09 log units), on the low side, and the stated range covers the measured number.
By their numbers in this assay, from the lowest: compounds 1, 2 and 3 (each within the scatter of the next).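

In this assay, trifluoromethyl in place of the group of 5 fluorine and 1 sulfur, on the aromatic carbon para to a large group, gives a 1.6-fold higher number from compound 1 to compound 3 (0.20 log units; within the scatter) and so no shift beyond the scatter at this position. Together with a 1.4-fold higher number from compound 1 to compound 2 (0.14 log units; within the scatter), this means that neither single exchange of a fluorinated group, each on a different aromatic carbon, moves the number beyond the scatter. No measurement here accounts for this result.

Every group shown at this position is fluorinated, so an amine or a carboxylic acid there remains open. Whether either would move the number beyond the scatter is also unknown.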